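Cyclobutyl for Difluorophenyl: Cytotoxicity Outlook for Compound 4

The source may report more compounds than this note shows. Statements on the series, on what has been measured and on what is new or still open speak of the compounds shown alone.

Compound 1, `CC(=O)N(CCCCCCN1C[C@H](O)[C@@H](O)[C@H](O)[C@H]1CO)C1CCCCC1`: in an ADME assay on BHK cells (Mesocricetus auratus) for cytotoxicity, read by MTT assay (on this read-out lower numbers stand for higher toxicity in this test and higher numbers for lower toxicity in this test), compound 1 reaches only the assay limit > 500000 nM.
Compound 2, `CC(C)(C)CC(=O)N(CCCCCCN1C[C@H](O)[C@@H](O)[C@H](O)[C@H]1CO)C1CCCCC1`: in this assay compound 2 reaches only the assay limit > 500000 nM.
Compound 3, `CC(C)(C)C(=O)N(CCCCCCN1C[C@H](O)[C@@H](O)[C@H](O)[C@H]1CO)c1ccc(F)cc1F`: in this assay compound 3 reaches only the assay limit > 500000 nM.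

Going by the values given here, the only measured step between neighbours is a step that the two limits leave unreadable from compound 1 to compound 2, so its size cannot be read. Compound 3 stands where the other two stand, at the limit: the limit of > 500000 nM in this assay, at which 3 of the 3 values shown sit. Compound 4, `CC(C)(C)C(=O)N(CCCCCCN1C[C@H](O)[C@@H](O)[C@H](O)[C@H]1CO)C1CCC1`, differs from compound 3 by cyclobutyl in place of 2,4-difluorophenyl on an amide-type nitrogen. Among the compounds with values here, no measured step gives a readable size, and no value shown is a number, so no change beyond the usual scatter is expected; the expected step is a number no higher from compound 3 to compound 4 (the limit leaves the size open). Compound 4 is therefore estimated at 500000 nM, with a range from 200000 nM to 1000000 nM, most likely again reported only as a limit.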

Compound 4, half-maximal cytotoxic concentration: > 500000 nM
Compound 4: a limit, no number; the forecaster's own chance of this, stated with the estimate: 85%; the middle value sits exactly at the limit.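

Compound 3 and compound 4 both give only limits, not numbers, in this assay, so no size can be read for the step between them. The compounds shown leave open at what concentration any of them becomes toxic to these cells: the limit of > 500000 nM in this assay, at which 4 of the 4 values shown sit.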